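Pyridyl Ether Variation and Thermodynamic Solubility

A few compounds are considered here, and "the series" means these few. Any claim that something is new, unique, unknown or untested is made for them only; others in the source may bear on it.

Measured compounds:
compound 1, `Cn1c(COc2cccc(C(=O)O)c2)nc2ccc(Oc3cccc(Cl)n3)cc21`: 7.7 ug/mL
compound 2, `Cc1ccc(Oc2ccc3nc(COc4cccc(C(=O)O)c4)n(C)c3c2)nc1`: 31 ug/mL
compound 3, `Cn1c(COc2cccc(C(=O)O)c2)nc2ccc(Oc3ncccc3F)cc21`: 7.1 ug/mL

In a physicochemical assay for solubility, read by HPLC, measured as thermodynamic solubility, with a stated time of 4 h, at pH 6.8 (on this read-out lower numbers stand for lower solubility and higher numbers for higher solubility), compound 3 gives the lowest of the three numbers, with compound 1 within the scatter of it and compound 2 clearly higher. Compound 4 `Cc1cc(F)cnc1Oc1ccc2nc(COc3cccc(C(=O)O)c3)n(C)c2c1` differs from compound 3 by 5-fluoro-3-methylpyridin-2-yl in place of 3-fluoropyridin-2-yl on an oxygen on an aromatic ring. Among the measured compounds shown here, two measured steps bear on this position: a 1.1-fold lower number from compound 1 to compound 3 (0.04 log units; within the scatter) stayed within the scatter, while a 4.4-fold lower number from compound 2 to compound 3 (0.64 log units; beyond the scatter) and a 4.0-fold higher number from compound 1 to compound 2 (0.60 log units; beyond the scatter) lay beyond it. For the measured compounds named here, no measured step pairs a fluorine with an added methyl on this pyridine. For compound 4 in this assay the number is therefore expected close to that of compound 3, giving a 1.1-fold higher number from compound 3 to compound 4 (0.05 log units; within the scatter). The estimate for compound 4 is 8 ug/mL, with a range from 3 ug/mL to 20 ug/mL.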

Compound 4, solubility: 14 ug/mL
For compound 4 the middle estimate is 1.8-fold (0.24 log units) below the measured one; the range from low to high includes it.
By their numbers in this assay, from the lowest: compounds 3, 1 and 4 (each within the scatter of the next); then compound 2.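

In this assay, the step to a pyridine bearing both fluorine and methyl gives a 2.0-fold higher number from compound 3 to compound 4 (0.29 log units; within the scatter), and a comparison with the chlorinated group gives a 1.8-fold higher number from compound 1 to compound 4 (0.26 log units; within the scatter), so 5-fluoro-3-methylpyridin-2-yl stays within the scatter of both 3-fluoropyridin-2-yl and 6-chloropyridin-2-yl. Only 5-methylpyridin-2-yl remains apart, with a 2.2-fold lower number from compound 2 to compound 4 (0.35 log units; beyond the scatter). Nothing measured here accounts for these differences.

The compounds shown leave open whether the methyl or the fluorine of 5-fluoro-3-methylpyridin-2-yl sets the place of compound 4. They also leave open how an amine or a methoxy group on this pyridine would read.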